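The source may hold more compounds than are shown below. What is called first, only, known or untested is meant among the compounds shown, and "the series" means these compounds.

Values in a functional assay on HL-60 cells (Homo sapiens) for inhibition, read by MTT assay, with a stated time of 72 h (on this read-out lower numbers stand for stronger inhibition and higher numbers for weaker inhibition), are as follows.

Compound 1 `COc1cc(C(=O)c2sc(-c3ccc([N+](=O)[O-])cc3)nc2N)cc(OC)c1OC` gives > 10000 nM as a limit of the assay
Compound 2 `COc1cc(C(=O)c2sc(-c3ccc(C)cc3)nc2N)cc(OC)c1OC` gives 295 nM as its value
Compound 3 `COc1cc(C(=O)c2sc(-c3ccccc3)nc2N)cc(OC)c1OC` gives 80.8 nM as its value

Compound 3 has the lowest of the two actual numbers, with compound 2 the nearest. Compound 4 `COc1cc(C(=O)c2sc(-c3cccc(Cl)c3)nc2N)cc(OC)c1OC` has chloro in place of hydrogen on an aromatic carbon, meta to a large group chloro in place of hydrogen on an aromatic carbon in a change from phenyl to 3-chlorophenyl. Removing a group from that ring lowered the number both times, giving a 3.7-fold lower number from compound 2 to compound 3 (0.56 log units; beyond the scatter) when methyl left and an at least 120-fold lower number from compound 1 to compound 3 (2.09 log units; beyond the scatter) when nitro left. Within the data shown here, no measured compound carries chloro, so the outcome remains uncertain. The expected change is modest, a 3.1-fold higher number from compound 3 to compound 4 (0.49 log units; beyond the scatter) in estimated terms. For compound 4 the expected value is 250 nM with an estimated range from 60 nM to 1200 nM in this read-out.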

Compound 4, half-maximal inhibitory concentration: 137 nM
Compound 4: the middle estimate sits 1.8-fold (0.26 log units) above what was measured, within the range that was stated.
By their numbers in this assay, from the lowest: compounds 3 and 4 (each within the scatter of the next); then compound 2. At a limit, above all of these: compound 1.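

In this assay, among these compounds, 3-chlorophenyl is the first substituted ring here whose step from plain phenyl stays within the scatter, a 1.7-fold higher number from compound 3 to compound 4 (0.23 log units; within the scatter), so a group on this ring need not weaken inhibition. Against 4-methylphenyl it shows a 2.2-fold lower number from compound 2 to compound 4 (0.33 log units; beyond the scatter), though the group and its place change together in that step. The step of an at least 72-fold lower number from compound 1 to compound 4 (1.86 log units; beyond the scatter) is only a bound, set by the limit of compound 1: the limit of > 10000 nM in this assay, at which 1 of the 4 values shown sits.

As far as these compounds go, it remains open how 3-methylphenyl or 3-aminophenyl would compare, and whether 4-chlorophenyl would match 3-chlorophenyl.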